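Carboxyethyl on the Aniline Nitrogen of Compound 1

A few compounds are considered here, and "the series" means these few. Any claim that something is new, unique, unknown or untested is made for them only; others in the source may bear on it.

Compound 1, `COc1cc(OC)c(/C=C/S(=O)(=O)Cc2ccc(OC)c(N)c2)c(OC)c1`, is the reference point of this series. In a functional assay on DU-145 cells (Homo sapiens) for cytotoxicity, read by trypan blue exclusion, with a stated time of 96 h (on this read-out higher numbers stand for weaker inhibition and lower numbers for stronger inhibition), compound 1 gives 4 nM, the lowest number of the three measured compounds. Compound 2, `COc1ccc(CS(=O)(=O)/C=C/c2c(OC)cc(OCCCC(=O)O)cc2OC)cc1N`, gives 25000 nM, and compound 3, `COc1cc(OC)c(/C=C/S(=O)(=O)Cc2ccc(Br)c(N)c2)c(OC)c1`, gives 750 nM. The two measured steps away from compound 1 both go the same way: a 6300-fold higher number from compound 1 to compound 2 (3.80 log units; beyond the scatter), and a 190-fold higher number from compound 1 to compound 3 (2.27 log units; beyond the scatter).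

Compound 4, `COc1cc(OC)c(/C=C/S(=O)(=O)Cc2ccc(OC)c(N[C@@H](C)C(=O)O)c2)c(OC)c1`, differs from compound 1 in one place: 1-carboxyethyl in place of hydrogen on a nitrogen on an aromatic ring. Within the data shown here, no measured step makes this exact change. The step from compound 1 to compound 2, which likewise brings in a chain ending in a carboxylic acid, though on an oxygen of the other ring, is the one that bears on it most, and it was very large; the step from compound 1 to compound 3 shows that the ring carrying the amino group also tolerates change poorly. The expectation is therefore a large loss for compound 4, of a size a 250-fold higher number from compound 1 to compound 4 (2.40 log units; beyond the scatter), though with wide uncertainty. Compound 4 is accordingly estimated at 1000 nM, within a range from 100 nM to 20000 nM, in this assay.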

Compound 4, half-maximal inhibitory concentration: 25 nM
Compound 4: middle estimate off by 40-fold (1.60 log units), on the high side; the measured number lies below the stated range.
By their numbers in this assay, from the lowest: compound 1; then compound 4; then compound 3; then compound 2.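

In this assay the nitrogen on an aromatic ring of compound 1 takes 1-carboxyethyl in place of hydrogen with only a modest loss, shown by a 6.3-fold higher number from compound 1 to compound 4 (0.80 log units; beyond the scatter) on this change, so a chain ending in a carboxylic acid is not in itself ruinous on the core of compound 1. The earlier step with such a chain, a 6300-fold higher number from compound 1 to compound 2 (3.80 log units; beyond the scatter) with 2-carboxyethyl on a saturated chain carbon bound to an oxygen on an aromatic ring, is far larger, and so across these two compounds the size of the loss differs with the place and the chain that enters. Nothing at hand explains the difference between these two steps.

The compounds shown leave open how much of the result belongs to the carboxylic acid and how much to the defined stereocentre, which the mirror-image 1-carboxyethyl group, its methyl ester or a plain ethyl group on the same nitrogen could separate. They also leave open whether a longer chain ending in a carboxylic acid, or an amide, would be accepted on this nitrogen as well.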